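Chloro pattern on the anilide in the cytotoxicity test

This account rests on a few compounds, and the source may have more. Where it says the series, first, only, none or still open, it means among the compounds named here.

Measured compounds:
compound 1 `Cn1cc(SCC(=O)Nc2ccccc2Cl)c2ccccc21` gives > 100000 nM in an ADME assay on HEK-293T cells (Homo sapiens) for cytotoxicity, read by CCK-8 assay, with a stated time of 48 h; on this read-out higher numbers stand for lower toxicity in this test and lower numbers for higher toxicity in this test
compound 2 `Cn1cc(SCC(=O)Nc2c(Cl)cccc2Cl)c2ccccc21` gives > 100000 nM
compound 3 `CCOc1ccccc1NC(=O)CSc1c[nH]c2cc(Cl)ccc12` gives > 100000 nM

The value of compound 1 is a limit of the assay, not a number. The value of compound 2 is likewise a limit. The value of compound 3 is a limit as well. Compound 1 therefore stands only at a limit, and the step that the two limits leave unreadable from compound 1 to compound 2 cannot be read in size or direction. Compound 4 `Cn1cc(SCC(=O)Nc2cccc(Cl)c2Cl)c2ccccc21` differs from compound 1 by chloro in place of hydrogen on an aromatic carbon, ortho to a chloro group and meta to a large group. For the measured compounds named here, the only step that bears on this change is the one from compound 1 to compound 2, which gives no readable size; with the limit of > 100000 nM in this assay, at which 3 of the 3 values shown sit, no step beyond the scatter is expected in this assay. The expected step is a step that the limit leaves unreadable from compound 1 to compound 4. Compound 4 is estimated at 150000 nM, between 60000 nM and 500000 nM, most likely reported again only as a limit.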

Compound 4, half-maximal cytotoxic concentration: > 100000 nM
Compound 4: only a limit was reported; the forecaster's own chance of this, stated with the estimate: 85%; the middle value does not contradict the limit.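

Compound 1 and compound 4 both stand only at a limit in this assay, so no new step can be read between them: the limit of > 100000 nM in this assay, at which 4 of the 4 values shown sit.

The compounds shown leave open whether chloro in place of hydrogen on an aromatic carbon changes this read-out at all.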